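Fluoro to ethynyl: an antiproliferative value still awaited

A few compounds are considered here, and "the series" means these few. Any claim that something is new, unique, unknown or untested is made for them only; others in the source may bear on it.

Measured so far in a functional assay on L1210 cells (Mus musculus) for antiproliferative activity, read by cell counting, with a stated time of 48 h; on this read-out lower numbers stand for stronger inhibition and higher numbers for weaker inhibition:
Compound 1 `C#C[C@@]1(O)[C@@H](CO)O[C@@H](n2cnc3c(-c4ccc(F)cc4)ncnc32)[C@@H]1O`: > 250000 nM (a limit)
Compound 2 `C#C[C@@]1(O)[C@@H](CO)O[C@@H](n2cc(F)c3c(N)ncnc32)[C@@H]1O`: 35 nM

For the measured compounds named here, compound 2, at 35 nM, holds the only actual number in this assay. Compound 1 reaches only a limit, > 250000 nM.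

Compound 3 `C#Cc1cn([C@@H]2O[C@H](CO)[C@](O)(C#C)[C@H]2O)c2ncnc(N)c12` has not yet been measured. It departs from compound 2 by a single change, ethynyl in place of fluoro on an aromatic carbon of a five-membered aromatic ring with 1 nitrogen. Going by the values given here, no measured pair shows what such a change does, so the expectation starts from compound 2 at 35 nM and stays broad. A moderate weakening in this assay is expected, though a result within the scatter would not surprise. The expected change is a 4.3-fold higher number from compound 2 to compound 3 (0.63 log units; beyond the scatter). For compound 3 the estimated value is 150 nM, with an expected range of 20 nM to 2500 nM.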

Compound 3, half-maximal inhibitory concentration: 159000 nM
For compound 3 the middle estimate is 1100-fold (3.03 log units) below the measured one; measured number outside the range, above it.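

Ethynyl in place of fluoro on this aromatic carbon, two ring bonds from the ring nitrogen, gives a 4500-fold higher number from compound 2 to compound 3 (3.66 log units; beyond the scatter) in this assay, the first measured sign that this position is highly sensitive to what it carries. Neither group has a hydrogen-bond donor or acceptor, and neither brings a ring or a net charge, so those counts do not separate the two compounds, yet the activity differs sharply. Compound 3 now reads toward the weak end of the values shown, where the only other weak entry is a limit held by compound 1: the limit of > 250000 nM in this assay, at which 1 of the 3 values shown sits.

The compounds shown leave open how a chlorine, a methyl or a vinyl group on this carbon would read in this assay. They therefore cannot tell whether the loss is specific to ethynyl or would follow any group other than fluoro.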